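The compounds below may be only part of what the source reports. "The series", "measured", "known", "first", "only" and "open" are said of these compounds alone.

Of the compounds shown here, two have so far been tested in a functional assay on MGC-803 cells (Homo sapiens) for inhibition, read by sulforhodamine B assay; a higher number here means a weaker inhibitor, a lower number a stronger inhibitor. Compound 1, `O=C1C(Nc2ccc(I)cc2)=CC(=O)c2c1nc1n2[C@H]2OC[C@@H](O)[C@H]2OC1`, gives 2150 nM in this assay. Compound 2, `O=C1C=C(Nc2cccc(F)c2)C(=O)c2c1nc1n2[C@H]2OC[C@@H](O)[C@H]2OC1`, gives 2180 nM in this assay. These two numbers lie within the usual scatter of one another, so compound 1 cannot be told apart from compound 2 on these data, even though its number is the lower of the two.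

The compound now awaiting measurement is compound 3, `O=C1C(N2CCCCC2)=CC(=O)c2c1nc1n2[C@H]2OC[C@@H](O)[C@H]2OC1`. It differs from compound 1 in one place: piperidin-1-yl in place of (4-iodophenyl)amino on a double-bonded ring carbon. Within the data shown here, no pair of measured compounds shows what such an exchange does in this assay, so the expectation rests on the change itself rather than on a measured step. A moderate weakening is expected, a step from compound 1 to compound 3 of a 2.1-fold higher number from compound 1 to compound 3 (0.32 log units; beyond the scatter), somewhat beyond the scatter. Compound 3 is therefore estimated at 4500 nM in this assay, within a range from 1500 nM to 14000 nM.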

Compound 3, half-maximal inhibitory concentration: > 4000 nM
Compound 3 ended at the assay's limit; the forecaster's own chance of this, stated with the estimate: 10%; the middle value lies beyond the limit too.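

In this assay, piperidin-1-yl in place of (4-iodophenyl)amino on a double-bonded ring carbon gives an at least 1.8-fold higher number from compound 1 to compound 3 (0.26 log units; that floor lies within the scatter). The reading for compound 3 is a limit of the assay and not a number: the limit of > 4000 nM in this assay, at which 1 of the 3 values shown sits. This first look at a non-aromatic ring at this position shows no gain in strength, but because the floor of the step lies within the scatter, a real loss is not established either, and the exchange removes both the aromatic ring and the hydrogen-bond donor at once.

The compounds shown leave open which of these two differences counts, if either does. Cyclohexylamino would keep the donor without the aromatic ring, whereas N-methyl-N-phenylamino would keep the aromatic ring without the donor.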